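Three Anilide Amides Tolerated at the Top Limit

The compounds below may be only part of what the source reports. "The series", "measured", "known", "first", "only" and "open" are said of these compounds alone.

Compound 1 `O=C(Nc1ccc(Cl)cc1F)c1ccccc1OCc1ccc(F)cc1F` carries a 4-chloro-2-fluorophenyl amide. In an ADME assay on RAW264.7 cells (Mus musculus) for cytotoxicity, read by MTT assay, with a stated time of 24 h (a higher number here means that more compound is tolerated, a lower number that less compound is tolerated), compound 1 gives > 40000 nM, which is a limit of the assay rather than a number. Compound 3 `O=C(Nc1ccc(F)cc1F)c1ccccc1OCc1ccc(F)cc1F` arises by the change (fluoro in place of chloro on an aromatic carbon). In this assay compound 3 gives > 40000 nM, again a limit. The step that the two limits leave unreadable from compound 1 to compound 3 therefore cannot be read in size, because of the limit of > 40000 nM in this assay, at which 3 of the 3 values shown sit.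

Compound 2 `O=C(Nc1ccc(Cl)cc1F)c1ccccc1` is the smaller core; the difference between the two cores of compound 1 and compound 2 is not broken down here. In this assay compound 2 gives > 40000 nM, a limit once more. Compound 4 `O=C(Nc1ccc(F)cc1F)c1ccccc1`, not yet measured, comes from compound 2 by fluoro in place of chloro on an aromatic carbon. This is the same kind of change as from compound 1 to compound 3, though there the position was para to a large group, here para to a group of 9 heavy atoms.

Given that all three measured values sit at the same limit, compound 4 is expected to show a step that the limit leaves unreadable from compound 2 to compound 4 and to land near 60000 nM, most likely again reported only as a limit.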

Compound 4, half-maximal cytotoxic concentration: > 40000 nM
Compound 4 gave a limit, no number; the forecaster's own chance of this, stated with the estimate: 85%; the middle value lies beyond the limit too.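

In this assay compound 2 and compound 4 both give limits rather than numbers, so the change from chloro to fluoro yields no readable step between these two compounds: the limit of > 40000 nM in this assay, at which 4 of the 4 values shown sit. The compounds shown leave open at what concentration any of them would become toxic to these cells, and whether chloro and fluoro compounds would differ there.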